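Heteroaryl replacement at the ring carbon of the core

The compounds below may be only part of what the source reports. "The series", "measured", "known", "first", "only" and "open" are said of these compounds alone.

Measured so far in a functional assay for antagonist activity at transient receptor potential cation channel subfamily V member 1 (Homo sapiens), read by FLIPR; on this read-out lower numbers stand for stronger inhibition and higher numbers for weaker inhibition:
- compound 1 `CC(C)(C)c1ccc(NC(=O)c2ccc(-c3ncccc3NS(C)(=O)=O)cc2)cc1`: 152 nM
- compound 2 `CC(C)(C)c1ccc(NC(=O)c2ccc(-c3ncccc3C(=O)O)cc2)cc1`: > 4000 nM
- compound 3 `CC(C)(C)c1ccc(NC(=O)c2ccc(-c3ncccc3-c3ncc[nH]3)cc2)cc1`: 3670 nM

Compound 3 holds the highest of the two numbers given; the nearest is compound 1, and the step of a 24-fold higher number from compound 1 to compound 3 (1.38 log units; beyond the scatter) is large. The value of compound 2 is a limit of this assay (the limit of > 4000 nM in this assay, at which 1 of the 3 values shown sits), so compound 2 and compound 3 cannot be ordered, which the step of an at least 1.0-fold lower number from compound 2 to compound 3 (0.03 log units; that floor lies within the scatter) shows.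

Compound 4 `CC(C)(C)c1ccc(NC(=O)c2ccc(-c3ncccc3-c3nnco3)cc2)cc1` is not yet measured. It differs from compound 3 by 1,3,4-oxadiazol-2-yl in place of 1H-imidazol-2-yl on an aromatic carbon. Among the measured compounds shown here, the steps that bear on this place are an at least 26-fold higher number from compound 1 to compound 2 (1.42 log units; beyond the scatter) and a 24-fold higher number from compound 1 to compound 3 (1.38 log units; beyond the scatter), both large in the same direction, whereas the change from carboxy to 1H-imidazol-2-yl left the number where it was. The entering 1,3,4-oxadiazol-2-yl is a third five-membered heteroaryl with neither the methanesulfonamido group of compound 1 nor a hydrogen-bond donor.

The number for compound 4 in this assay is therefore expected to stay close to that of compound 3, with a step of a 1.1-fold higher number from compound 3 to compound 4 (0.04 log units; within the scatter) or none beyond the scatter. The estimate for compound 4 is 4000 nM, within 1500 nM to 12000 nM, and a limit rather than a number is a real possibility.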

Compound 4, half-maximal inhibitory concentration: 91 nM
Beside the measured number, compound 4's estimate is 44-fold (1.64 log units) above it; measured number below the stated range.
By their numbers in this assay, from the lowest: compounds 4 and 1 (each within the scatter of the next); then compound 3. At a limit, above all of these: compound 2.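

In this assay, 1,3,4-oxadiazol-2-yl in place of 1H-imidazol-2-yl gives a 40-fold lower number from compound 3 to compound 4 (1.61 log units; beyond the scatter), so a five-membered aromatic ring on this aromatic carbon does not by itself carry the weak number of compound 3. The step of a 1.7-fold lower number from compound 1 to compound 4 (0.22 log units; within the scatter) lies within the scatter, so methanesulfonamido is not the only group shown at this place that keeps the number low. The step of an at least 43-fold lower number from compound 2 to compound 4 (1.64 log units; beyond the scatter) is only a floor, as the value of compound 2 is a limit: the limit of > 4000 nM in this assay, at which 1 of the 4 values shown sits.

The compounds shown do not separate the ring oxygen of compound 4 from the hydrogen-bond donor that leaves with 1H-imidazol-2-yl. An oxazol-2-yl or a methyl on the 1,3,4-oxadiazol-2-yl ring would test how narrow this tolerance is.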